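This account rests on a few compounds, and the source may have more. Where it says the series, first, only, none or still open, it means among the compounds named here.

Measured compounds and values:
compound 1 `CC(=O)Nc1ccc(S(=O)(=O)Oc2ccccc2C(C)C)cc1` gives 23000 nM
compound 2 `CC(=O)Nc1ccc(S(=O)(=O)Oc2ccccc2I)cc1` gives 23000 nM
compound 3 `CC(C)c1ccccc1OS(=O)(=O)c1ccc(NC(=O)NCC2CCCC2)cc1` gives 6800 nM

All three were run in a functional assay on HT-29 cells (Homo sapiens) for antiproliferative activity, read by sulforhodamine B assay, with a stated time of 48 h; on this read-out higher numbers stand for weaker inhibition and lower numbers for stronger inhibition. Compound 1 and compound 2 share a core and differ by iodo in place of isopropyl on an aromatic carbon; the step of no change at the digits printed from compound 1 to compound 2 (within the scatter). Compound 3 differs from compound 1 by (cyclopentylmethyl)amino in place of methyl on a carbonyl carbon, and the step of a 3.4-fold lower number from compound 1 to compound 3 (0.53 log units; beyond the scatter). Among the three, compound 3 has the lowest number, with its steps to compound 1 and compound 2 both beyond the scatter.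

Compound 4 `O=C(NCC1CCCC1)Nc1ccc(S(=O)(=O)Oc2ccccc2I)cc1` has not yet been measured. It differs from compound 3 by iodo in place of isopropyl on an aromatic carbon, and the place of that change is the same as in the pair compound 1 to compound 2, so the change is the same one already seen. The two cores differ by (cyclopentylmethyl)amino in place of methyl on a carbonyl carbon.

Since the step of no change at the digits printed from compound 1 to compound 2 (within the scatter), the same change applied to compound 3 is expected to leave the number about where it stands. The step from compound 3 to compound 4 is therefore estimated as no change at the digits printed from compound 3 to compound 4 (within the scatter) in this assay, resting on the single earlier occurrence of the change and on compound 3 giving 6800 nM. Compound 4 is accordingly estimated at 6800 nM in this assay, with a range from 3000 nM to 15000 nM. The basis is one matched pair only, so the uncertainty is wide.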

Compound 4, half-maximal inhibitory concentration: 7600 nM
Compound 4: middle estimate off by 1.1-fold (0.05 log units), on the low side, and the stated range covers the measured number.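

In this assay, iodo in place of isopropyl on the aromatic carbon gives a 1.1-fold higher number from compound 3 to compound 4 (0.05 log units; within the scatter), and this step carries from the core of compound 1 to the core of compound 3 without a difference that can be told from scatter: the same change on two cores in this assay, no change at the digits printed (within the scatter) from compound 1 to compound 2 and a 1.1-fold higher number (0.05 log units; within the scatter) from compound 3 to compound 4, 1.1-fold (0.05 log units) apart, within the scatter of two such steps. Read the other way, (cyclopentylmethyl)amino in place of methyl on the carbonyl carbon gives a 3.0-fold lower number from compound 2 to compound 4 (0.48 log units; beyond the scatter), and that gain holds whichever of the two aromatic groups is present: the same change on two cores in this assay, a 3.4-fold lower number (0.53 log units; beyond the scatter) from compound 1 to compound 3 and a 3.0-fold lower number (0.48 log units; beyond the scatter) from compound 2 to compound 4, 1.1-fold (0.05 log units) apart, within the scatter of two such steps. Across these four compounds the two changes therefore behave independently, but this rests on a single square of two cores and two groups, and on a swap that barely moves the number, so it does not show that a change with a large effect at this place would carry over equally, nor does it give any reason for the result.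

The compounds shown leave open whether a hydrogen, a fluoro or a methoxy group in place of iodo or isopropyl would also leave the number unchanged. They also leave open what an amine, a carboxylic acid or a longer chain in place of the cyclopentylmethyl group would do in this assay.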